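Working notes: 1-phenylethyl for 2-fluorobenzyl on the shared core

The compounds below may be only part of what the source reports. "The series", "measured", "known", "first", "only" and "open" are said of these compounds alone.

Compound 1, `Cc1ccc(-c2nc(N)c3ccsc3n2)o1`, carries the bare core; in a functional assay on CHO-K1 cells for antagonist activity at adenosine receptor A1 (Homo sapiens), read by a beta-galactosidase reporter and cAMP accumulation, with stated times of 15 min and 6 h (a lower number here means a stronger inhibitor, a higher number a weaker inhibitor), compound 1 gives 493 nM. Compound 2, `Cc1ccc(-c2nc(N)c3cc(Cc4ccccc4F)sc3n2)o1`, adds a 2-fluorobenzyl group on an aromatic carbon. For compound 2 this assay reports only a limit, < 16 nM, not a number. Within the data shown here, the step of an at least 30-fold lower number from compound 1 to compound 2 (1.48 log units; beyond the scatter) is the only measured step in the set, and its true size is open because of the limit of < 16 nM in this assay, at which 1 of the 2 values shown sits. Compound 2 thus stands at the limit of the assay, and no measured value separates it from anything stronger.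

Compound 3, `Cc1ccc(-c2nc(N)c3cc(C(C)c4ccccc4)sc3n2)o1`, changes the substituent at that position: 1-phenylethyl in place of 2-fluorobenzyl on an aromatic carbon. Both groups are of the same size and both carry a single carbon-only aromatic ring one carbon away from the core. The step from compound 1 to compound 2 shows that a group of this kind at this position is what carries the gain; whether the methyl branch and the loss of fluorine move the number is not covered by any measured step. The expectation is a step of an at least 1.2-fold higher number from compound 2 to compound 3 (0.09 log units; that floor lies within the scatter), within the scatter, and compound 3 is estimated at 20 nM, between 5 nM and 80 nM.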

Compound 3, inhibition constant: 439 nM
Compound 3: the middle estimate sits 22-fold (1.34 log units) below what was measured; measured number above the stated range.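

Putting 1-phenylethyl in place of 2-fluorobenzyl on the aromatic carbon next to the ring sulfur gives, in this assay, an at least 27-fold higher number from compound 2 to compound 3 (1.43 log units; beyond the scatter). The gain at this position therefore does not extend to every group with one six-membered aromatic ring of carbon only and the same heavy-atom count: with 1-phenylethyl in place of hydrogen, the data show a 1.1-fold lower number from compound 1 to compound 3 (0.05 log units; within the scatter), which leaves compound 3 within the scatter of the bare core. On these data alone, the exact size of the loss on going from 2-fluorobenzyl to 1-phenylethyl stays open because compound 2 is known only as a limit: the limit of < 16 nM in this assay, at which 1 of the 3 values shown sits.

The methyl branch and the fluorine change together in this pair, and the compounds shown do not separate their contributions. As far as these compounds go, whether unsubstituted benzyl, which has neither the branch nor the fluorine, would sit with compound 2 or with compound 3 remains open, as does the outcome for 2-chlorobenzyl or for an amine at this position.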